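Swapping Carboxy for Ethyl on the Side Chain

A few compounds are considered here, and "the series" means these few. Any claim that something is new, unique, unknown or untested is made for them only; others in the source may bear on it.

In a functional assay on HCT-116 cells (Homo sapiens) for antiproliferative activity, read by sulforhodamine B assay, with a stated time of 72 h (on this read-out higher numbers stand for weaker inhibition and lower numbers for stronger inhibition), compound 1 `Cn1ncc(Cl)c1-c1cc(C(=O)N[C@@H]2CN[C@H](CCCO)C[C@H]2c2ccc(Cl)c(Cl)c2)oc1Cl` gives 510 nM and compound 2 `Cn1ncc(Cl)c1-c1cc(C(=O)N[C@@H]2CN[C@H](CCN3CCCCC3)C[C@H]2c2ccc(Cl)c(Cl)c2)oc1Cl` gives 1020 nM on the shared core, while compound 3 `Cn1ncc(Cl)c1-c1cc(C(=O)N[C@@H]2CN[C@H](CC(=O)O)C[C@H]2c2ccc(Cl)c(Cl)c2)oc1Cl` gives 4020 nM and stands highest of the three, the weakest inhibitor here. Compound 4 `CCC[C@@H]1C[C@@H](c2ccc(Cl)c(Cl)c2)[C@H](NC(=O)c2cc(-c3c(Cl)cnn3C)c(Cl)o2)CN1` has ethyl in place of carboxy on a saturated chain carbon bound to a saturated ring carbon, a change counted as ethyl in place of carboxy on a saturated chain carbon bound to a saturated ring carbon and also readable as carboxymethyl to propyl. Within the data shown here, two measured steps bear on it: a 7.9-fold higher number from compound 1 to compound 3 (0.90 log units; beyond the scatter) and a 3.9-fold higher number from compound 2 to compound 3 (0.60 log units; beyond the scatter) are both modest and beyond the scatter, each arriving at the carboxy compound from a chain without carboxy. The remaining step of a 2.0-fold higher number from compound 1 to compound 2 (0.30 log units; within the scatter) lies within the scatter, so those two chains cannot be told apart. Among the measured compounds shown here, no measured compound carries propyl, so the expectation rests on these comparisons alone. Removing carboxy should reverse a step of similar size, and in this assay the expected move is a 5.7-fold lower number from compound 3 to compound 4 (0.76 log units; beyond the scatter) toward stronger inhibition. The value estimated for compound 4 is 700 nM with 220 nM to 2200 nM as its expected range.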

Compound 4, half-maximal inhibitory concentration: 1020 nM
Beside the measured number, compound 4's estimate is 1.5-fold (0.16 log units) below it; measured number inside the range.
By their numbers in this assay, from the lowest: compounds 1, 2 and 4 (each within the scatter of the next); then compound 3.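

In this assay, ethyl in place of carboxy gives a 3.9-fold lower number from compound 3 to compound 4 (0.60 log units; beyond the scatter), and the resulting propyl chain lands level with the other two chains: no change at the digits printed from compound 2 to compound 4 (within the scatter) and a 2.0-fold higher number from compound 1 to compound 4 (0.30 log units; within the scatter), both within the scatter. The hydroxy and piperidin-1-yl ends therefore show no measurable gain over a chain of carbon alone, and among these four compounds only the carboxy chain stands apart, with the higher number. No measurement shown here explains why this chain differs from the rest. As far as these compounds go, it remains open whether a methyl ester or a primary amine in place of the carboxy would read like compound 3 or like compound 4. Also unresolved is how a longer carbon chain, such as butyl or pentyl, would fare at this position.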